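A few compounds are considered here, and "the series" means these few. Any claim that something is new, unique, unknown or untested is made for them only; others in the source may bear on it.

Measured so far:
Compound 1 `CC(O)c1cnc(N2CCC(c3coc4c(N5CCc6cc(S(C)(=O)=O)ccc65)ncnc34)CC2)nc1` — in a functional assay on cells for agonist activity at Glucose-dependent insulinotropic receptor (Homo sapiens), read by a luciferase reporter, with a stated time of 4 h (on this read-out lower numbers stand for an effect already at smaller amounts and higher numbers for an effect only at larger amounts of compound), compound 1 gives 586 nM.
Compound 2 `CC(C)(C)OC(=O)N1CCC(c2coc3c(N4CCc5cc(S(C)(=O)=O)ccc54)ncnc23)CC1` — in this assay compound 2 gives 53 nM.

Among these two numbers, compound 2 holds the lower one, and its only neighbour is compound 1, separated by the step of an 11-fold lower number from compound 1 to compound 2 (1.04 log units; beyond the scatter). Compound 3 `CS(=O)(=O)c1ccc2c(c1)CCN2c1ncnc2c(C3CCN(c4ncc(O)cn4)CC3)coc12` is still to be measured in this assay. It differs from compound 2 in a single place: 5-hydroxypyrimidin-2-yl in place of tert-butoxycarbonyl on an amine nitrogen in a ring.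

For the measured compounds named here, only one measured step bears on this change, the step of an 11-fold lower number from compound 1 to compound 2 (1.04 log units; beyond the scatter), in which a pyrimidin-2-yl group carrying a 1-hydroxyethyl group on the ring amine nitrogen was exchanged for tert-butoxycarbonyl, and the number fell sharply. The change to compound 3 runs the other way: tert-butoxycarbonyl leaves and a pyrimidin-2-yl returns, now as 5-hydroxypyrimidin-2-yl rather than the 1-hydroxyethyl form seen in compound 1. Whether the different group on the pyrimidine shifts the outcome cannot be read from the two measured compounds. A step upward of roughly the size seen between compound 1 and compound 2 is therefore expected, landing near compound 1.

Compound 3 is expected to give 450 nM in this assay, within 120 nM to 1700 nM. That estimate means a step of an 8.5-fold higher number from compound 2 to compound 3 (0.93 log units; beyond the scatter).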

Compound 3, half-maximal effective concentration: 391 nM
The estimate for compound 3 lay 1.2-fold (0.06 log units) above the measured number, within the range that was stated.
By their numbers in this assay, from the lowest: compound 2; then compounds 3 and 1 (each within the scatter of the next).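

In this assay, putting 5-hydroxypyrimidin-2-yl in place of tert-butoxycarbonyl on the ring amine nitrogen gives a 7.4-fold higher number from compound 2 to compound 3 (0.87 log units; beyond the scatter). A second pyrimidin-2-yl group therefore sits on the high-number side of compound 2, so the earlier gap no longer rests on a single pyrimidine compound. The two pyrimidine groups themselves cannot be told apart on this read-out: hydroxy in place of 1-hydroxyethyl on an aromatic carbon gives a 1.5-fold lower number from compound 1 to compound 3 (0.18 log units; within the scatter), which means that among these three compounds the clear divide lies between tert-butoxycarbonyl and the pyrimidin-2-yl groups, not between the two groups carried on the pyrimidine.

No measurement shown here explains why the numbers divide this way. On these data alone, it remains open whether a pyrimidin-2-yl group carrying an amine or a carboxylic acid in place of the hydroxy would stay level with compound 3 or come closer to compound 2, and whether a carbamate with a smaller group than tert-butyl, such as ethyl, would keep the low number of compound 2.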